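Benzoyl for Acetyl on a Leukotriene Receptor Ligand

A few compounds are considered here, and "the series" means these few. Any claim that something is new, unique, unknown or untested is made for them only; others in the source may bear on it.

Compound 1 `CC(=O)c1cc(C(C)=O)c(OCCCCC#N)cc1O` — 8%
Compound 2 `C=CCc1cc(C(C)=O)c(O)cc1OCCCCC#N` — 92%

In an assay on isolated protein for inhibition of leukotriene B4 receptor 1 (Homo sapiens), tested at 10 uM (on this read-out lower numbers stand for less inhibition and higher numbers for more inhibition at the one concentration tested (going by the name of the read-out)), compound 2 gives 92% and stands highest of the two numbers shown. Its nearest neighbour is compound 1, which gives 8% in this assay. Going by the values given here, the one measured step is a number 84 percentage points higher from compound 1 to compound 2 (beyond the scatter), a change of allyl in place of acetyl on an aromatic carbon.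

Compound 3 `C=CCc1cc(C(=O)c2ccccc2)c(O)cc1OCCCCC#N` differs from compound 2 at a different place: phenyl in place of methyl on a carbonyl carbon. No measured step touches the carbonyl substituent, so none of the shown data bears directly on this change. Because the starting number 92% for compound 2 lies close to the upper end of the scale, a step upward beyond the scatter is hardly possible; what is expected is a step of a number 14 percentage points lower from compound 2 to compound 3 (beyond the scatter), downward or within the scatter. Compound 3 is therefore estimated at 78%, in a range from 40% to 96%.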

Compound 3, a percentage reported as inhibition, at one concentration (the size of the read-out at that concentration, not a potency): 33%
For compound 3 the middle estimate is 45 percentage points above the measured one; the whole stated range lies above it.
By their numbers in this assay, from the lowest: compound 1; then compound 3; then compound 2.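

In this assay the change of acetyl to benzoyl gives a number 59 percentage points lower from compound 2 to compound 3 (beyond the scatter) and so shows that the group on the carbonyl carbon has a large bearing on this read-out. The earlier step, a number 84 percentage points higher from compound 1 to compound 2 (beyond the scatter) with allyl in place of acetyl on an aromatic carbon, had shown this only for a different place on the shared core, and it left the methyl on the carbonyl carbon of compound 2 untested. No measurement at hand accounts for the loss seen with phenyl.

From the compounds shown here alone, whether any group other than methyl on this carbonyl carbon would give the same loss stays open, for ethyl or a cyclopropyl ring as much as for a benzyl group. Going by these compounds, how a carboxylic acid in place of the nitrile would read alongside the allyl and the acetyl of compound 2 also remains open.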